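A few compounds are considered here, and "the series" means these few. Any claim that something is new, unique, unknown or untested is made for them only; others in the source may bear on it.

Compound 1 `CCN(CC)C(=O)Nc1ccc2cc[nH]c2c1` carries a urea on the shared core, compound 2 `CCN(CC)C(=O)Oc1ccc2cc[nH]c2c1` a carbamate; the difference between the two cores is not broken down here. In an assay on isolated protein for inhibition of Amine oxidase [flavin-containing] B (Homo sapiens), read by fluorescence, with stated times of 10 min, 10 s and 20 min (on this read-out higher numbers stand for weaker inhibition and lower numbers for stronger inhibition), compound 1 gives only a limit of the assay, > 100000 nM. Compound 2 likewise gives only a limit in this assay, > 100000 nM. Compound 3 `C#CCn1ccc2ccc(NC(=O)N(CC)CC)cc21` differs from compound 1 by propargyl in place of hydrogen on an aromatic nitrogen, and in this assay compound 3 gives 2620 nM, so that an at least 38-fold lower number from compound 1 to compound 3 (1.58 log units; beyond the scatter). Compound 4 `C#CCn1ccc2ccc(OC(=O)N(CC)CC)cc21` stands to compound 2 as compound 3 stands to compound 1, by propargyl in place of hydrogen on an aromatic nitrogen, the same change at the same place. Because (the limit of > 100000 nM in this assay, at which 2 of the 3 values shown sit), the step from compound 2 can be read from one side only. For compound 4 a value near 1500 nM is expected in this assay. That estimate means an at least 66-fold lower number from compound 2 to compound 4 (1.82 log units; beyond the scatter), set beside an at least 38-fold lower number from compound 1 to compound 3 (1.58 log units; beyond the scatter) as its basis. The expected range for compound 4 runs from 300 nM to 8000 nM.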

Compound 4, half-maximal inhibitory concentration: 1840 nM
Compound 4: the middle estimate sits 1.2-fold (0.09 log units) below what was measured; measured number inside the range.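

In this assay, propargyl in place of hydrogen on an aromatic nitrogen again goes with stronger inhibition on the carbamate of compound 2, giving an at least 54-fold lower number from compound 2 to compound 4 (1.73 log units; beyond the scatter), so the change carries over to the second of the two cores shown. The two steps are set side by side as follows: the same change on two cores in this assay, an at least 38-fold lower number (1.58 log units; beyond the scatter) from compound 1 to compound 3 and an at least 54-fold lower number (1.73 log units; beyond the scatter) from compound 2 to compound 4; the limit leaves it open whether they differ. Both steps start from a limit, so neither gives an exact size and the data do not show whether the core alters the effect of the change: the limit of > 100000 nM in this assay, at which 2 of the 4 values shown sit.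

Open, from the compounds shown here alone, is whether the triple bond matters, as a plain propyl or an allyl group on the same nitrogen would show. Also open, going by these compounds, is whether the change carries to cores bearing an amide or a simple amine in place of the urea or carbamate.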